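Furan in Place of Methoxyphenyl: Expected Paw Edema Inhibition

This account rests on a few compounds, and the source may have more. Where it says the series, first, only, none or still open, it means among the compounds named here.

Measured compounds in a functional assay on the whole organism (strain albino) for inhibition, with Rattus norvegicus as the target, read by paw edema, with stated times of 30 min and 5 h, at a dose of 100 mg/kg by the oral route; on this read-out higher numbers stand for more inhibition at the one dose given (going by the name of the read-out) and lower numbers for less inhibition:
compound 1 `CC(=O)c1ccc(OCC(=O)Nc2ccc(C(=O)/C=C/c3ccco3)cc2)cc1` gives 36%
compound 2 `C/C(=N/O)c1ccc(OCC(=O)Nc2ccc(C(=O)/C=C/c3ccc(Cl)cc3)cc2)cc1` gives 49%
compound 3 `COc1ccc(/C=C/C(=O)c2ccc(NC(=O)COc3ccc(/C(C)=N\O)cc3)cc2)cc1` gives 37%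

Compound 3 sits within the scatter of compound 1, while a number 12 percentage points lower from compound 2 to compound 3 (beyond the scatter) puts it beyond the scatter under compound 2. Compound 4 `C/C(=N/O)c1ccc(OCC(=O)Nc2ccc(C(=O)/C=C/c3ccco3)cc2)cc1` differs from compound 3 by furan-2-yl in place of 4-methoxyphenyl on a double-bonded chain carbon bound to a double-bonded chain carbon. Among the compounds with values here, no measured step covers this change directly; compound 1 carries the same furan-2-yl, but its difference from compound 4 lies in another part of the molecule, so only the chloro-to-methoxy step of compound 2 to compound 3 shows how far this end of the molecule can move the number. For compound 4, a step of a number 3 percentage points higher from compound 3 to compound 4 (within the scatter) in this assay is expected, that is, none beyond the scatter. Compound 4 is therefore estimated at 40%, between 28% and 52%.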

Compound 4, a percentage reported as inhibition, in the whole organism at one dose (the size of the read-out at that dose, not a potency): 42%
For compound 4 the middle estimate is 2 percentage points below the measured one, and the stated range covers the measured number.
By their numbers in this assay, from the lowest: compounds 1, 3, 4 and 2 (each within the scatter of the next, the first and the last beyond it).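

Furan-2-yl in place of 4-methoxyphenyl gives a number 5 percentage points higher from compound 3 to compound 4 (within the scatter), and in place of 4-chlorophenyl it gives a number 7 percentage points lower from compound 2 to compound 4 (within the scatter), so at this position furan-2-yl cannot be told apart from either group, even though those two differ from each other beyond the scatter. The change on an aromatic carbon, a group of 4 heavy atoms in place of a group of 3, gives a number 6 percentage points higher from compound 1 to compound 4 (within the scatter), so it too has no effect that can be told from the scatter. Nothing available explains these numbers. On these data alone, what stays open is how a thiophen-2-yl or a 4-aminophenyl at this position would read.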